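This account rests on a few compounds, and the source may have more. Where it says the series, first, only, none or still open, it means among the compounds named here.

In an ADME assay on L1210/0 cells (Mus musculus) for cytotoxicity, with a stated time of 48 h (a higher number here means a weaker inhibitor, a lower number a stronger inhibitor), compound 1 `OC[C@@H]1C[C@H](Cn2cnc3c(NC4CC4)ncnc32)c2c(-c3ccccc3)nnc(-c3ccccc3)c21` is reported as > 200000 nM, which is a limit of the assay and not a number. For the measured compounds named here, compound 2 `O=c1[nH]c(=O)n([C@H]2C[C@H](O)[C@@H](CO)O2)cc1CO` gives 9180 nM, the only actual number available so far. The two structures are too far apart to form a single step, so compound 2 has no close measured neighbour to be compared with.

The step followed here leads to compound 3 `C=Cc1cn([C@H]2C[C@H](O)[C@@H](CO)O2)c(=O)[nH]c1=O`, which keeps the rest of compound 2 and has vinyl in place of hydroxymethyl on an aromatic carbon. Going by the values given here, no measured pair shows what this swap does in this assay, so any expectation is a rough one and has to start from compound 2 at 9180 nM. The estimated change a 1.3-fold higher number from compound 2 to compound 3 (0.12 log units; within the scatter) is expected to stay within the usual scatter, with no firm direction. A real move either way cannot be ruled out, so the range is kept wide. For compound 3 the expected value is 12000 nM, with an estimated range from 2500 nM to 60000 nM.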

Compound 3, half-maximal inhibitory concentration: 14200 nM
Compound 3: the middle estimate sits 1.2-fold (0.07 log units) below what was measured; low and high end bracket the measured number.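

Vinyl in place of hydroxymethyl on an aromatic carbon gives a 1.5-fold higher number from compound 2 to compound 3 (0.19 log units; within the scatter) in this assay, the first step that can be read at this position. Hydroxymethyl, with one hydrogen-bond donor and one hydrogen-bond acceptor, gives way here to vinyl, with neither, and the read-out shows no change that can be told apart from the normal spread of repeated measurements, although this single pair speaks only for this one swap. Compound 1 alone stands at a limit of the assay rather than at a number, so the step between the other two compounds is a comparison of two real values: the limit of > 200000 nM in this assay, at which 1 of the 3 values shown sits.

Still open, as far as these compounds go, is whether a group of a different kind at this same position, such as an amine, a carboxylic acid or a longer chain, would move the number beyond the scatter in either direction. Also open, from the compounds shown here alone, is whether vinyl in place of hydroxymethyl would behave the same way on any other core, since a single pair on one core cannot answer that.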